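The compounds below may be only part of what the source reports. "The series", "measured", "known", "first", "only" and "open" are said of these compounds alone.

Measured compounds:
- compound 1 `Cc1cccc(NC(=O)C(Cl)Cl)c1` — in a functional assay on Bel-7402 cells (Homo sapiens) for antiproliferative activity, read by MTT assay, with a stated time of 72 h (on this read-out higher numbers stand for weaker inhibition and lower numbers for stronger inhibition), compound 1 gives "not determined" (no result reported).
- compound 2 `O=C(Nc1cccc(I)c1)C(Cl)Cl` — in this assay compound 2 gives 5390 nM.

Working notes. Compound 1 stands nowhere on the numbers: it carries no reading, so its place in the series cannot be fixed from the data shown. Going by the values given here, the only number in hand belongs to compound 2, whose iodine sits on the same aromatic carbon of the shared core that carries the methyl of compound 1.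

The step under consideration leads from compound 1 to compound 3 `O=C(Nc1cccc(SC(F)(F)F)c1)C(Cl)Cl`, which is to be measured in this assay. The change: (trifluoromethyl)sulfanyl in place of methyl on an aromatic carbon. The (trifluoromethyl)sulfanyl enters on an aromatic carbon of a six-membered aromatic ring of carbon only, meta to a group of 6 heavy atoms.

Among the compounds with values here, no pair of measured compounds differing in one place is available, so the size of the step cannot be read off. As a substituent at the same place, the iodine of compound 2 gives 5390 nM, which is the nearest anchor. On that basis no step beyond the scatter is expected in either direction.

Compound 3 is expected to give about 4500 nM in this assay, estimated between 1500 nM and 14000 nM.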

Compound 3, half-maximal inhibitory concentration: 6540 nM
For compound 3 the middle estimate is 1.5-fold (0.16 log units) below the measured one; the measured number falls inside the stated range.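

In this assay, the aromatic carbon of the shared core now carries two substituents with readable numbers, and (trifluoromethyl)sulfanyl in place of iodo gives a 1.2-fold higher number from compound 2 to compound 3 (0.08 log units; within the scatter), a step within the usual scatter of the read-out. At this place, therefore, the two groups cannot be told apart on this read-out, and the (trifluoromethyl)sulfanyl group with its 5 heavy atoms keeps the number of the iodo compound within that scatter. Compound 1 gives "not determined" (no result reported), so the exchange of methyl itself still cannot be read, and the comparison rests on the iodo compound alone. No measurement shown bears on why the two substituents read alike.

Going by these compounds, whether an amine, a carboxylic acid or a longer alkyl chain on the same aromatic carbon would give a step beyond the scatter stays open. Going by these compounds alone, with only two numbers in hand, no trend can be stated for this place, and the effect of a change elsewhere on the shared core is also open.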